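Bromo in place of methyl: compound 1 to compound 3

The source may hold more compounds than are shown below. What is called first, only, known or untested is meant among the compounds shown, and "the series" means these compounds.

In an ADME assay on MT4 cells (Homo sapiens) for cytotoxicity, read by MTT assay (on this read-out higher numbers stand for lower toxicity in this test and lower numbers for higher toxicity in this test), compound 1 (`COc1ccc(-n2ccnc2SCC(=O)Nc2ccccc2C)cc1`) gives > 353000 nM, which is a limit of the assay and not a number. Compound 2 (`Cc1ccc(-n2ccnc2SCC(=O)Nc2ccccc2C)cc1`) gives 147000 nM in this assay. Going by the values given here, the one measured step is an at least 2.4-fold lower number from compound 1 to compound 2 (0.38 log units; beyond the scatter), with methyl in place of methoxy on an aromatic carbon. Its size is itself bounded, since it starts from the limit of > 353000 nM in this assay, at which 1 of the 2 values shown sits.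

Compound 3 (`COc1ccc(-n2ccnc2SCC(=O)Nc2ccccc2Br)cc1`) keeps the methoxy group of compound 1 and changes the other substituent: bromo in place of methyl on an aromatic carbon. This is bromo in place of methyl, 2-methylphenyl to 2-bromophenyl, ortho to a large group.

Among the compounds with values here, no measured step covers this swap. The step to compound 2, an at least 2.4-fold lower number from compound 1 to compound 2 (0.38 log units; beyond the scatter), concerns a different group and serves only as a loose guide to how far a single substitution can move the number in this series. A modest move to a lower number in this assay is therefore expected, though a further reading at a limit would not be surprising. The expected step is an at least 2.0-fold lower number from compound 1 to compound 3 (0.31 log units; beyond the scatter). For compound 3 the estimated value is 170000 nM, with an expected range from 50000 nM to 320000 nM.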

Compound 3, half-maximal cytotoxic concentration: > 298000 nM
Compound 3 ended at the assay's limit; the forecaster's own chance of this, stated with the estimate: 35%; middle value at least 1.7-fold (0.24 log units) from the limit.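

No step can be read for bromo in place of methyl between compound 1 and compound 3 in this assay: both readings are limits and not numbers. For compound 3, the limit is > 298000 nM. The compounds shown leave open whether this swap moves the number at all, and in which direction.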